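A few compounds are considered here, and "the series" means these few. Any claim that something is new, unique, unknown or untested is made for them only; others in the source may bear on it.

Within the data shown here, compound 2 `Fc1ccc(Nc2nc(SCc3ccc(C(F)(F)F)cc3)nc3ccccc23)cc1` holds the only number in a functional assay on MCF7 cells (Homo sapiens) for cytotoxicity, read by MTT assay, with a stated time of 72 h (on this read-out higher numbers stand for weaker inhibition and lower numbers for stronger inhibition), where compound 2 gives 36300 nM. Compound 1 `COc1ccccc1Nc1nc(SCc2ccc(C(F)(F)F)cc2)nc2ccccc12` is known in this assay only as a limit, > 50000 nM. The step of an at least 1.3-fold lower number from compound 1 to compound 2 (0.13 log units; that floor lies within the scatter) is accordingly floored by the limit of > 50000 nM in this assay, at which 1 of the 2 values shown sits, and stays within the scatter. Compound 3 `COc1ccc(Nc2nc(SCc3ccc(C(F)(F)F)cc3)nc3ccccc23)cc1` differs from compound 2 in one place: methoxy in place of fluoro on an aromatic carbon. Among the measured compounds shown here, the single measured step bears on this change only loosely: it exchanged 2-methoxyphenyl for 4-fluorophenyl, whereas compound 3 carries 4-methoxyphenyl, so the methoxy returns to the amino-bearing phenyl at a different named position. For the measured compounds named here, that step was small, and nothing else is known, so no step in this assay beyond the scatter is expected in either direction. The estimate for compound 3 is 40000 nM (range 15000 nM to 110000 nM), a step of a 1.1-fold higher number from compound 2 to compound 3 (0.04 log units; within the scatter) that is expected to lie within the scatter.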

Compound 3, half-maximal inhibitory concentration: 47200 nM
Compound 3: the middle estimate sits 1.2-fold (0.07 log units) below what was measured; low and high end bracket the measured number.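

Methoxy in place of fluoro on this aromatic carbon, para to a large group, gives a 1.3-fold higher number from compound 2 to compound 3 (0.11 log units; within the scatter) in this assay, so the 4-fluorophenyl and 4-methoxyphenyl groups cannot be told apart here. The comparison of 4-methoxyphenyl with 2-methoxyphenyl gives an at least 1.0-fold lower number from compound 1 to compound 3 (0.02 log units; that floor lies within the scatter), and its floor rests on a limit for compound 1, so the true size of this step cannot be read: the limit of > 50000 nM in this assay, at which 1 of the 3 values shown sits.

Going by these compounds, whether an amine, a carboxylic acid or a longer chain in place of methoxy on this aromatic carbon would give a step beyond the scatter remains open. Also open, on these data alone, is whether replacing the trifluoromethyl group on the shared core would change the number in this assay.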